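Methyl in place of vinyl on the aryl ether oxygen

This account rests on a few compounds, and the source may have more. Where it says the series, first, only, none or still open, it means among the compounds named here.

Measured so far:
compound 1 `C=COc1ccccc1OC(C)C1=NCCN1` 631 nM
compound 2 `Cc1cccc(C)c1OC(C)C1=NCCN1` 27.5 nM

Compound 1 `C=COc1ccccc1OC(C)C1=NCCN1` carries a vinyloxy group on the shared core. In a functional assay on CHO cells for agonist activity at Alpha-2C adrenergic receptor (Homo sapiens) (a lower number here means that less compound is needed, a higher number that more compound is needed for the effect), compound 1 gives 631 nM, the highest of the two numbers recorded. Its nearest neighbour is compound 2 `Cc1cccc(C)c1OC(C)C1=NCCN1`, which in this assay gives 27.5 nM; the gap between these two compounds lies beyond the usual scatter, with compound 2 needing less compound for the effect.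

Compound 3 `COc1ccccc1OC(C)C1=NCCN1` has not yet been tested. It differs from compound 1 in one place: methyl in place of vinyl on an oxygen on an aromatic ring. Going by the values given here, no step between two measured compounds corresponds to this change, so its size has to be estimated. Compound 3 is expected to move by a 2.5-fold lower number from compound 1 to compound 3 (0.40 log units; beyond the scatter), a modest shift towards a lower number. The estimate for compound 3 in this assay is 250 nM, with a range from 80 nM to 800 nM.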

Compound 3, half-maximal effective concentration: 9770 nM
Estimate against measurement, compound 3: 39-fold (1.59 log units) below; measured number outside the range, above it.
By their numbers in this assay, from the lowest: compound 2; then compound 1; then compound 3.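

Exchanging vinyl for methyl on an oxygen on an aromatic ring, the change of vinyloxy to methoxy, gives in this assay a 15-fold higher number from compound 1 to compound 3 (1.19 log units; beyond the scatter) and so means that more compound is needed for the effect. The exchange removes only one carbon and the double bond outside aromatic rings, with no hydrogen-bond donor or acceptor leaving or entering, so even this small change at this position moves the number a long way. Nothing available explains why the position responds so strongly.

The compounds shown leave open whether the carbon count or the double bond carries the step: an ethyl on the same oxygen would keep the two carbons of vinyl without its double bond. As far as these compounds go, how a longer chain such as propyl, or an amine, would read at this position in this assay also stays open.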